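A few compounds are considered here, and "the series" means these few. Any claim that something is new, unique, unknown or untested is made for them only; others in the source may bear on it.

Measured so far in an in vitro ADME assay on microsomes from liver (Homo sapiens) for pharmacokinetics, read by LC-MS, with a stated time of 10 min, tested at 1 uM; a lower number here means slower removal, a higher number faster removal of the compound:

compound 1, `CN1C[C@H](C(=O)Nc2ccc(Br)cc2)[C@@H](c2ccc(/C=C/C(=O)Nc3ccccc3N)cc2)C1`: 3 mL/min/kg
compound 2, `CN1C[C@H](C(=O)Nc2ccc(F)c(Cl)c2)[C@@H](c2ccc(/C=C/C(=O)Nc3ccccc3N)cc2)C1`: 15 mL/min/kg
compound 3, `CC(C)NC(=O)[C@H]1CN(C)C[C@@H]1c1ccc(/C=C/C(=O)Nc2ccccc2N)cc1`: 8 mL/min/kg

Compound 2 carries the largest of the three numbers in this assay, yet its gap to compound 3, a 1.9-fold lower number from compound 2 to compound 3 (0.27 log units; within the scatter), lies within the scatter, and only the gap from compound 1, a 5.0-fold higher number from compound 1 to compound 2 (0.70 log units; beyond the scatter), is beyond it. Compound 4, `CN1C[C@H](C(=O)NC2CC2)[C@@H](c2ccc(/C=C/C(=O)Nc3ccccc3N)cc2)C1`, is not yet measured; it differs from compound 2 by cyclopropyl in place of 3-chloro-4-fluorophenyl on an amide-type nitrogen. Within the data shown here, the step that bears most on this change is the one from compound 2 to compound 3, where a small branched group in place of the same aromatic ring gave a 1.9-fold lower number from compound 2 to compound 3 (0.27 log units; within the scatter), within the scatter. The step from compound 1 to compound 3, a 2.7-fold higher number from compound 1 to compound 3 (0.43 log units; beyond the scatter), shows that the amide substituent can move the number modestly. On this basis compound 4 is expected to give a somewhat lower number than compound 2, an estimated 1.9-fold lower number from compound 2 to compound 4 (0.27 log units; within the scatter), though possibly within the scatter. Compound 4 is therefore estimated at 8 mL/min/kg, with a range from 3 mL/min/kg to 20 mL/min/kg.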

Compound 4, clearance: 10 mL/min/kg
Estimate against measurement, compound 4: 1.3-fold (0.10 log units) below; measured number inside the range.
By their numbers in this assay, from the lowest: compound 1; then compounds 3, 4 and 2 (each within the scatter of the next).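

In this assay, cyclopropyl on the amide-type nitrogen cannot be told apart from the 3-chloro-4-fluorophenyl it replaces (a 1.5-fold lower number from compound 2 to compound 4 (0.18 log units; within the scatter)) or from isopropyl (a 1.3-fold higher number from compound 3 to compound 4 (0.10 log units; within the scatter)), so a group of 3 heavy atoms and one of 8 fall within the scatter at this position. Compound 1 alone stands apart (a 3.3-fold higher number from compound 1 to compound 4 (0.52 log units; beyond the scatter)). Compound 2 also carries an aromatic ring, and it goes against any reading that an aromatic ring on this nitrogen sets the low number. Nothing available accounts for why the 4-bromophenyl group separates from the others.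

As far as these compounds go, it remains open whether a chain ending in an amine or a carboxylic acid at this nitrogen would move the number beyond the scatter. From the compounds shown here alone, whether a longer alkyl chain would do so is also open.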